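The source may report more compounds than this note shows. Statements on the series, on what has been measured and on what is new or still open speak of the compounds shown alone.

Compound 1, `CC(=O)Oc1ccccc1C(=O)O[C@H]1CO[C@H]2[C@@H]1OC[C@H]2OC(=O)c1ccc(-c2ccccc2)cc1`. In an ADME assay on a cell-free system (plasma, Homo sapiens) for metabolic stability, with Plasma (Rattus norvegicus) as the target, read by HPLC, at pH 7.4 (on this read-out lower numbers stand for a shorter-lived compound and higher numbers for a longer-lived compound), compound 1 gives > 0.333 h, which is a limit of the assay rather than a number.
Compound 2, `CC(=O)Oc1ccccc1C(=O)O[C@H]1CO[C@H]2[C@@H]1OC[C@H]2OC(=O)c1cnoc1C`. In this assay compound 2 gives 0.193 h.

Among the measured compounds shown here, compound 2 carries the only plain number here; the other value is a limit, as the limit of > 0.333 h in this assay, at which 1 of the 2 values shown sits, makes clear. For the measured compounds named here, the one measured step, an at least 1.7-fold lower number from compound 1 to compound 2 (0.23 log units; that floor lies within the scatter), has a floor that sits within the scatter, so it says only that compound 2 may be somewhat shorter-lived than compound 1.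

Compound 3, `CC(=O)Oc1ccccc1C(=O)O[C@H]1CO[C@H]2[C@@H]1OC[C@H]2OC(=O)c1cccc(CO[N+](=O)[O-])c1`, differs from compound 2 in one place: 3-((nitrooxy)methyl)phenyl in place of 5-methyl-1,2-oxazol-4-yl on a carbonyl carbon. Going by the values given here, this change swaps the group on the same carbonyl carbon as the measured step did, so that step is the only guide. Since the move away from a six-membered carbon ring lowered the number, moving back to one is expected to give a small rise, a 1.6-fold higher number from compound 2 to compound 3 (0.19 log units; within the scatter), of a size that may stay within the scatter. Compound 3 is therefore estimated at 0.3 h, between 0.15 h and 0.6 h.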

Compound 3, half-life: 0.0433 h
Compound 3: the middle estimate sits 6.9-fold (0.84 log units) above what was measured; the measured number lies below the stated range.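

In this assay, 3-((nitrooxy)methyl)phenyl on this carbonyl carbon gives a 4.5-fold lower number from compound 2 to compound 3 (0.65 log units; beyond the scatter), so the group at this place can move the half-life by more than the scatter, which the earlier step could not show. The same group in place of 4-phenylphenyl gives an at least 7.6-fold lower number from compound 1 to compound 3 (0.88 log units; beyond the scatter), so a six-membered aromatic ring of carbon does not by itself go with a longer-lived compound, as compound 1 and compound 3 both carry one. That step is only a floor, since compound 1 has a limit of the assay and not a number: the limit of > 0.333 h in this assay, at which 1 of the 3 values shown sits.

The compounds shown leave open whether the drop belongs to the nitrooxy part or to the rest of the entering group. A plain phenyl on the same carbonyl carbon would help to separate the two.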